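From cyano to methoxy on compound 3

The compounds below may be only part of what the source reports. "The series", "measured", "known", "first", "only" and "open" are said of these compounds alone.

In an ADME assay on MT4 cells (Homo sapiens) for cytotoxicity, read by MTT assay, with a stated time of 5 days (a higher number here means that more compound is tolerated, a lower number that less compound is tolerated), compound 1 `COc1cc2nc(Nc3ccc(C#N)cc3)nc(Nc3c(F)cc(/C=C/C#N)cc3F)c2cc1OC` gives 6400 nM and compound 2 `COc1cc2nc(Nc3ccc(C#N)cc3)nc(Nc3c(C)cc(/C=C/C#N)cc3C)c2cc1OC` gives 10200 nM as measured numbers. Compound 3 `COc1cc2nc(SCC(=O)Nc3ccc(C#N)cc3)nc(Nc3c(C)cc(/C=C/C#N)cc3C)c2cc1OC` gives > 227000 nM as a limit of the assay, not a number. Compound 4 `COc1ccc(NC(=O)CSc2nc(Nc3c(C)cc(/C=C/C#N)cc3C)c3cc(OC)c(OC)cc3n2)cc1` differs from compound 3 in one place: methoxy in place of cyano on an aromatic carbon, para to a large group (methoxy in place of cyano on an aromatic carbon). Within the data shown here, the only measured step is a 1.6-fold higher number from compound 1 to compound 2 (0.20 log units; within the scatter) and it concerns another part of the molecule, which leaves it little bearing on this swap. Among the measured compounds shown here, no measured step exchanges these two groups, and no change beyond the scatter is expected in this assay here, though another limit may appear. The expected result is an at least 1.2-fold lower number from compound 3 to compound 4 (0.10 log units; that floor lies within the scatter) for this swap. Compound 4 is estimated at 180000 nM (range 60000 nM to 300000 nM).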

Compound 4, half-maximal cytotoxic concentration: > 225000 nM
Compound 4: no number, only a limit; the forecaster's own chance of this, stated with the estimate: 60%; middle value at least 1.2-fold (0.09 log units) away from the limit.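

Compound 3 and compound 4 each give only a limit of the assay, not a number, so the step from cyano to methoxy cannot be read. The compounds shown leave open whether this swap changes how much compound is tolerated.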